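The compounds below may be only part of what the source reports. "The series", "measured", "known", "first", "only" and "open" are said of these compounds alone.

The study concerns a small set of compounds built on a shared core and examined in a functional assay on MIA PaCa-2 cells (Homo sapiens) for antiproliferative activity, read by MTT assay, with a stated time of 72 h; a lower number here means a stronger inhibitor, a higher number a weaker inhibitor. Compound 1, `Cc1c(CC(O)CO)n(COCC[Si](C)(C)C)c(=O)[nH]c1=O`, is one of them. In this assay compound 1 returns only a limit, > 100000 nM. Compound 2, `COCn1c(CC(O)COCc2ccccc2)c(C)c(=O)[nH]c1=O`, carries a benzyl group on an oxygen on a saturated carbon. In this assay compound 2 likewise returns only a limit, > 100000 nM. Where compound 2 stands is thus fixed only as a bound: the two values shown both sit at the limit of > 100000 nM in this assay, at which 2 of the 2 values shown sit, so no number exists against which a step could be measured. Compound 3, `COCn1c(CC(O)CO)c(C)c(=O)[nH]c1=O`, is not yet measured. It differs from compound 2 by hydrogen in place of benzyl on an oxygen on a saturated carbon. Within the data shown here, no step between measured compounds is available, and compound 1 and compound 2, which differ in more than one place, each give only a limit. The expectation for compound 3 is that it too stays at the limit, with the expected step being a number no higher from compound 2 to compound 3 (the limit leaves the size open), none beyond the scatter. Compound 3 is estimated at 100000 nM, within a range from 40000 nM to 300000 nM, most likely reported again as a limit.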

Compound 3, half-maximal inhibitory concentration: > 100000 nM
Compound 3 gave a limit, no number; the forecaster's own chance of this, stated with the estimate: 85%; the middle value lies on the limit itself.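

In this assay compound 3 returns only a limit, so no step from compound 2 or compound 1 to compound 3 can be read, and all three compounds share one bound: the limit of > 100000 nM in this assay, at which 3 of the 3 values shown sit.

The compounds shown leave open how far each lies beyond that limit, and whether any change on the shared core would yield a number.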